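A few compounds are considered here, and "the series" means these few. Any claim that something is new, unique, unknown or untested is made for them only; others in the source may bear on it.

Measured so far in an ADME assay on MT4 cells (Homo sapiens) for cytotoxicity, with a stated time of 5 days (a lower number here means that less compound is tolerated, a higher number that more compound is tolerated), are three compounds.
- compound 1 `CC(C)N(c1cc(C#CC(C)(C)C)sc1C(=O)O)C(=O)[C@H]1CC[C@H](C)CC1` gives > 20000 nM as a limit
- compound 2 `CC(C)N(C(=O)C1CCCCC1)c1cc(C#CC(C)(C)C)sc1C(=O)O` gives > 20000 nM as a limit
- compound 3 `CC(C)N(C(=O)[C@H]1CC[C@@H]2C[C@@H]2CC1)c1cc(C#CC(C)(C)C)sc1C(=O)O` gives > 20000 nM as a limit

Compound 3 has no number, only the limit of > 20000 nM in this assay, at which 3 of the 3 values shown sit, to place it. Compound 4 `CC(C)N(C(=O)C1CCCCCC1)c1cc(C#CC(C)(C)C)sc1C(=O)O` differs from it by a group of 7 heavy atoms (7 carbon; one seven-membered non-aromatic ring of carbon only) in place of a group of 8 heavy atoms (8 carbon; one three-membered non-aromatic ring of carbon only, one seven-membered non-aromatic ring of carbon only), on a carbonyl carbon with cycloheptyl entering on a carbonyl carbon. Among the compounds with values here, the steps that bear on this are a step that the two limits leave unreadable from compound 2 to compound 3 and a step that the two limits leave unreadable from compound 1 to compound 3 together with a step that the two limits leave unreadable from compound 1 to compound 2 at the same group. None of the three has a readable size, and none points in a direction. The expected step that the limit leaves unreadable from compound 3 to compound 4 is therefore nothing beyond the scatter, in either direction. For compound 4 the estimate is 25000 nM within a range of 12000 nM to 50000 nM and a report of the limit alone is the expected outcome.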

Compound 4, half-maximal cytotoxic concentration: > 20000 nM
Compound 4 gave a limit, no number; the forecaster's own chance of this, stated with the estimate: 85%; the middle value does not contradict the limit.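

No step among compound 1, compound 2, compound 3 and compound 4 can be read in this assay, as each gives only a limit: the limit of > 20000 nM in this assay, at which 4 of the 4 values shown sit.

The compounds shown leave open at what concentration any of them becomes cytotoxic, and whether the group on the carbonyl carbon changes that concentration.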